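Swapping amino for iodo in an inactive series

The source may hold more compounds than are shown below. What is called first, only, known or untested is meant among the compounds shown, and "the series" means these compounds.

Compound 1 `COC(=O)c1cccc(Oc2ccc(N(C)C)cc2)c1`: > 20000 nM, a limit.
Compound 2 `COC(=O)c1ccc(Oc2ccc(OC)cc2)c(N)c1`: > 20000 nM, a limit.
Compound 3 `COC(=O)c1ccc(Oc2ccc(OC)c(OC)c2)c(N)c1`: > 20000 nM, a limit.

In a functional assay on HL-60 cells (Homo sapiens) for antiproliferative activity (a higher number here means a weaker inhibitor, a lower number a stronger inhibitor), compound 3 gives > 20000 nM, which is a limit and not a number. It has no better-placed neighbour: the limit of > 20000 nM in this assay, at which 3 of the 3 values shown sit. Compound 4 `COC(=O)c1ccc(Oc2ccc(OC)c(OC)c2)c(I)c1` differs from it by one change, (iodo in place of amino on an aromatic carbon), with iodo in place of amino on an aromatic carbon. Among the compounds with values here, the only measured step is a step that the two limits leave unreadable from compound 2 to compound 3, and it gives no size to build on. Within the data shown here, no measured step replaces amino with iodo, so the expectation stays loose, and only a move toward stronger inhibition could be read. The expected step is an at least 2.0-fold lower number from compound 3 to compound 4 (0.30 log units; that floor lies within the scatter). For compound 4 the estimated value is 10000 nM, with an expected range of 1000 nM to 30000 nM.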

Compound 4, half-maximal inhibitory concentration: 5620 nM
Beside the measured number, compound 4's estimate is 1.8-fold (0.25 log units) above it; measured number inside the range.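

Within the data shown here, replacing amino with iodo on this aromatic carbon gives an at least 3.5-fold lower number from compound 3 to compound 4 (0.55 log units; beyond the scatter) in this assay, the first step with a readable size. On these data alone, its full size stays unknown, as the value of compound 3 is a limit. Compound 4 is the only compound shown with a number rather than a limit: the limit of > 20000 nM in this assay, at which 3 of the 4 values shown sit.

The compounds shown leave open whether bromo, chloro or methyl at this position would do the same as iodo. They also leave open whether a carboxylic acid in place of the methoxycarbonyl group would keep the activity of compound 4.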